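Aryl swap on the dienone chain: compound 3

The source may hold more compounds than are shown below. What is called first, only, known or untested is meant among the compounds shown, and "the series" means these compounds.

Measured so far:
Compound 1, `CC1=CCCC(C)(C)C1/C=C/C(=O)/C=C/c1ccccc1C(F)(F)F`: in a functional assay on CWR22R cells (Homo sapiens) for cytotoxicity, read by MTT assay, with a stated time of 72 h (a lower number here means a stronger inhibitor, a higher number a weaker inhibitor), compound 1 gives 18400 nM.
Compound 2, `CC1=CCCC(C)(C)C1/C=C/C(=O)/C=C/c1ccccc1F`: in this assay compound 2 gives 9400 nM.

Compound 2 holds the lowest of the two numbers; its nearest neighbour is compound 1, and the step of a 2.0-fold lower number from compound 1 to compound 2 (0.29 log units; within the scatter) stays within the scatter. Compound 3, `CC1=CCCC(C)(C)C1/C=C/C(=O)/C=C/c1cccc(C)c1`, is not yet measured. The change is 3-methylphenyl in place of 2-fluorophenyl on a double-bonded chain carbon bound to a double-bonded chain carbon. Among the compounds with values here, no measured step covers this change: the only step seen, from compound 1 to compound 2, exchanged one substituent for another on the same ring and moved the number little. Little beyond the scatter is expected here. Compound 3 is estimated at 9000 nM in this assay, range 3000 nM to 30000 nM. The expected step is a 1.0-fold lower number from compound 2 to compound 3 (0.02 log units; within the scatter).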

Compound 3, half-maximal inhibitory concentration: 15200 nM
The estimate for compound 3 lay 1.7-fold (0.23 log units) below the measured number; measured number inside the range.
By their numbers in this assay, from the lowest: compounds 2, 3 and 1 (each within the scatter of the next).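

Putting 3-methylphenyl in place of 2-fluorophenyl on a double-bonded chain carbon bound to a double-bonded chain carbon gives a 1.6-fold higher number from compound 2 to compound 3 (0.21 log units; within the scatter) in this assay and so no readable change. At this position, an aryl group with a methyl substituent therefore joins the fluorine-bearing aryl groups of compound 1 and compound 2 without separating from them. No evidence on hand bears on this result.

Still open, going by these compounds, is whether any aryl substituent moves the number beyond the scatter. An amine or a carboxylic acid on the phenyl ring would test this.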